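Cinnamamide series at melanin-concentrating hormone receptor 1: compound 4

The compounds below may be only part of what the source reports. "The series", "measured", "known", "first", "only" and "open" are said of these compounds alone.

Measured so far:
- compound 1, `CCCc1cc(N)c2cc(NC(=O)/C=C/c3ccc(CC)cc3)ccc2n1`: 160 nM
- compound 2, `CCCc1cc(N)c2cc(NC(=O)/C=C/c3ccc(C(C)(C)C)cc3)ccc2n1`: 910 nM
- compound 3, `CCCc1cc(NC2CCC2)c2cc(NC(=O)/C=C/c3ccc(C(F)(F)F)cc3)ccc2n1`: 270 nM

All three values come from a functional assay on HEK293 cells for activation of melanin-concentrating hormone receptor 1 (Homo sapiens), read by inositol phosphate accumulation; a higher number here means that more compound is needed for the effect, a lower number that less compound is needed. Compound 1 gives the lowest number of the three; compound 3 sits closest to it, and that gap is within the scatter, so no order between compound 1 and compound 3 can be read. Compound 2 lies furthest away, and the step of a 5.7-fold higher number from compound 1 to compound 2 (0.75 log units; beyond the scatter) is beyond the scatter (modest). Within the data shown here, compound 3 differs from compound 1 in more than one place, so no single step is drawn from it.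

Compound 4, `CCCc1cc(N)c2cc(NC(=O)/C=C/c3ccccc3Cl)ccc2n1`, is not yet measured. Relative to compound 1 the change is 2-chlorophenyl in place of 4-ethylphenyl on a double-bonded chain carbon bound to a double-bonded chain carbon.

Among the measured compounds shown here, the only measured step on the same aryl group, a 5.7-fold higher number from compound 1 to compound 2 (0.75 log units; beyond the scatter), concerns a change of alkyl size, not the exchange made here; it therefore bears on compound 4 only loosely. Nothing measured covers a 2-chlorophenyl. For the measured compounds named here, the one relevant step raised the number, so a step in the same direction, but of uncertain size, is expected: a 2.5-fold higher number from compound 1 to compound 4 (0.40 log units; beyond the scatter) is the estimated change. Compound 4 is thus expected to give about 400 nM in this assay, with a range from 120 nM to 1500 nM.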

Compound 4, half-maximal effective concentration: 500 nM
Compound 4: middle estimate off by 1.3-fold (0.10 log units), on the low side; the range from low to high includes it.
By their numbers in this assay, from the lowest: compounds 1, 3, 4 and 2 (each within the scatter of the next, the first and the last beyond it).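

In this assay the exchange of 4-ethylphenyl for 2-chlorophenyl on a double-bonded chain carbon bound to a double-bonded chain carbon gives a 3.1-fold higher number from compound 1 to compound 4 (0.49 log units; beyond the scatter) and so extends the reading at this position beyond a change of alkyl size. Among these compounds with the same core, both exchanges at this aryl group, the 4-tert-butylphenyl of compound 2 and the 2-chlorophenyl of compound 4, raise the number relative to compound 1, with none going against this; compound 4 (500 nM) and compound 2 (910 nM) lie within the scatter of each other, so no order can be read between those two aryl groups. No measurement at hand accounts for the rise seen with compound 4.

Going by these compounds, this exchange alters the substituent and its place on the ring together, so it remains open whether the higher number follows the chlorine or its place; values for 4-chlorophenyl and 2-ethylphenyl would separate the two. Also open, on these data alone, is how an unsubstituted phenyl or a 4-methoxyphenyl would read against compound 1, which would show whether any substituent at all is needed on this ring.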